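Bromo on the phenyl of a coumarin-lipoic acid hybrid

This account rests on a few compounds, and the source may have more. Where it says the series, first, only, none or still open, it means among the compounds named here.

Two compounds are known here. Compound 1 `CC(=O)c1cc2ccc(OCCCCCn3cc(CNC(=O)CCCCC4CCSS4)nn3)cc2oc1=O` carries an acetyl group on its shared core, and in a functional assay on PC-12 cells (Rattus norvegicus) for cytotoxicity, read by MTT assay, with stated times of 3 h and 2 h, tested at 5 uM (a lower number here means a weaker effect, a higher number a stronger effect of the compound at the concentration tested), compound 1 gives 22.2%. Compound 2 `O=C(CCCCC1CCSS1)NCc1cn(CCCCCOc2ccc3cc(-c4ccccc4)c(=O)oc3c2)nn1` carries a phenyl instead, and in this assay compound 2 gives 28%. Among the measured compounds shown here, the single step between them, a number 5.8 percentage points higher from compound 1 to compound 2 (within the scatter), lies within the scatter, so compound 2 and compound 1 are not distinguished by these numbers.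

Compound 3 `O=C(CCCCC1CCSS1)NCc1cn(CCCCCOc2ccc3cc(-c4ccc(Br)cc4)c(=O)oc3c2)nn1` differs from compound 2 in one place: bromo in place of hydrogen on an aromatic carbon. For the measured compounds named here, no measured step concerns a bromo on this phenyl, so nothing here speaks for a change; the one step measured, a number 5.8 percentage points higher from compound 1 to compound 2 (within the scatter), was itself within the scatter. The expected step is therefore none beyond the scatter, a number 2 percentage points higher from compound 2 to compound 3 (within the scatter). For compound 3 in this assay the estimate is 30%, with a range from 18% to 42%.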

Compound 3, a percentage reported as activity, at one concentration (the size of the read-out at that concentration, not a potency): 45.7%
Estimate against measurement, compound 3: 15.7 percentage points below; measured number outside the range, above it.
By their numbers in this assay, from the lowest: compounds 1 and 2 (each within the scatter of the next); then compound 3.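

Among the compounds shown here, the phenyl on the shared core is not a silent place in this assay: a single added bromine atom, turning phenyl into 4-bromophenyl, gives a number 17.7 percentage points higher from compound 2 to compound 3 (beyond the scatter), the first step larger than the usual variation between repeats. Plain phenyl could not be told apart from acetyl, yet 4-bromophenyl can, with a number 23.5 percentage points higher from compound 1 to compound 3 (beyond the scatter), which puts compound 3 at the top of the three. The data offer no measurement that explains why the bromo has this effect.

From the compounds shown here alone, whether a chloro, a methoxy or an amine in the same place on the phenyl would give a similar number remains open, as does the effect of a bromo elsewhere on that ring. Each read-out also comes from one concentration, so the potency of these compounds remains open too.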